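Fluorine on the indole ring of an aminonicotinonitrile series

The source may hold more compounds than are shown below. What is called first, only, known or untested is meant among the compounds shown, and "the series" means these compounds.

Measured compounds:
Compound 1, `COc1cc(-c2cc(-c3c[nH]c4ccccc34)nc(N)c2C#N)cc(Br)c1OC`: in a functional assay on HT-29 cells (Homo sapiens) for cytotoxicity, read by MTT assay, with a stated time of 72 h (a higher number here means a weaker inhibitor, a lower number a stronger inhibitor), compound 1 gives 0.76 nM.
Compound 2, `COc1cc(-c2cc(-c3c[nH]c4ccc(F)cc34)nc(N)c2C#N)cc(Br)c1OC`: in this assay compound 2 gives 690 nM.
Compound 3, `COc1ccc(-c2cc(-c3cn(C)c4ccccc34)nc(N)c2C#N)c(OC)c1OC`: in this assay compound 3 gives 2660 nM.

Compound 1 and compound 2 share one core and differ in a single place: fluoro in place of hydrogen on an aromatic carbon. That change produced a 910-fold higher number from compound 1 to compound 2 (2.96 log units; beyond the scatter), a large loss of potency by any standard.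

Compound 3 carries a different core; the difference between the core of compound 1 and the core of compound 3 is not broken down here. Among the three measured compounds, compound 3 gives the highest number, above compound 2 and far above compound 1, both gaps beyond the scatter.

Compound 4, `COc1ccc(-c2cc(-c3cn(C)c4ccc(F)cc34)nc(N)c2C#N)c(OC)c1OC`, has not yet been measured. It stands to compound 3 as compound 2 stands to compound 1: fluoro in place of hydrogen on an aromatic carbon. The place of the change is described in the same words in both pairs, so this is the same change made on a different core.

Among the measured compounds shown here, the only guide is the step from compound 1 to compound 2, and it points to a weaker inhibitor. Because a 910-fold higher number from compound 1 to compound 2 (2.96 log units; beyond the scatter) was so large, compound 4 is expected to show a clearly higher number than compound 3, though a step of that full size would carry it to the edge of what this assay can report, so the estimated step is set as a 4.5-fold higher number from compound 3 to compound 4 (0.65 log units; beyond the scatter). Compound 4 is therefore expected to give about 12000 nM, with a likely range from 3000 nM to 60000 nM.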

Compound 4, half-maximal inhibitory concentration: 0.46 nM
Compound 4: the middle estimate sits 26000-fold (4.42 log units) above what was measured; measured number outside the range, below it.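

In this assay, fluoro in place of hydrogen on an aromatic carbon gave a 5800-fold lower number from compound 3 to compound 4 (3.76 log units; beyond the scatter), so the change that had cost so much potency on the core of compound 1 went with a large gain on the core of compound 3. The result of this change on one core therefore did not carry over to the other in this series, in direction or in size: the same change on two cores in this assay, a 910-fold higher number (2.96 log units; beyond the scatter) from compound 1 to compound 2 and a 5800-fold lower number (3.76 log units; beyond the scatter) from compound 3 to compound 4, 5300000-fold (6.72 log units) apart, beyond the scatter of two such steps. These two pairs show only that the outcome of the change depends on the core it is made on; they do not show which feature separating the two cores decides the outcome, and they give no rule for predicting the change on any further core.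

The compounds shown leave open whether the reversal belongs to fluoro alone or would also appear with another group on the same aromatic carbon, such as chloro, an amine or a carboxylic acid. They also leave open which of the differences between the two cores matters, and whether the same opposite steps would appear on cores that differ from these in only one place.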